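The source may report more compounds than this note shows. Statements on the series, on what has been measured and on what is new or still open speak of the compounds shown alone.

Working notes on the series. In an ADME assay on cells (Homo sapiens) for antiproliferative activity, read by MTT assay (on this read-out lower numbers stand for stronger inhibition and higher numbers for weaker inhibition), compound 1 (`O=C(N/N=C/c1ccccn1)c1ccc(O)cc1`) gives > 80000 nM. This is a limit of the assay and not a number, so compound 1 has no exact starting value.

Compound 2 (`C/C(=N\NC(=O)c1ccc(N)cc1)c1cnccn1`), which also carries an amino group on an aromatic carbon, gives a measured 58800 nM. Going by the values given here, no step between measured compounds isolates a single change, so there is no direct precedent for the next comparison.

Compound 3 (`Nc1ccc(C(=O)N/N=C/c2ccccn2)cc1`) keeps the core of compound 1 and changes one place: amino in place of hydroxy on an aromatic carbon. In words, this is amino in place of hydroxy on an aromatic carbon, para to a large group.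

Among the compounds with values here, the only guide to the size of the change is compound 2 at 58800 nM, a weak but measurable value from an amino-bearing member of the series. The expected change is an at least 1.7-fold lower number from compound 1 to compound 3 (0.24 log units; that floor lies within the scatter), a modest move toward stronger inhibition, and a result that stays at the limit of the assay remains possible. For compound 3 the estimated value is 45000 nM, with an expected range of 12000 nM to 80000 nM.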

Compound 3, half-maximal inhibitory concentration: > 80000 nM
Compound 3: no number, only a limit (the forecaster's own chance of this, stated with the estimate: 30%); middle value at least 1.7-fold (0.24 log units) away from the limit.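

Compound 1 and compound 3 both give only a limit and not a number in this assay, so no step can be read for amino in place of hydroxy on an aromatic carbon between them: the limit of > 80000 nM in this assay, at which 2 of the 3 values shown sit.

The compounds shown leave open whether this change moves the value at all, and if so, in which direction and by how much.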